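This account rests on a few compounds, and the source may have more. Where it says the series, first, only, none or still open, it means among the compounds named here.

Measured so far:
compound 1 `CN1CCN(CCCOc2cccc3nc(Nc4ccc(F)c(F)c4)ccc23)CC1`: 2350 nM
compound 2 `CN1CCN(CCCOc2cccc3nc(Nc4cc(Cl)cc(Cl)c4)ccc23)CC1`: 1720 nM

In a functional assay on KM12 cells (Homo sapiens) for inhibition, read by sulforhodamine B assay, with a stated time of 48 h (a higher number here means a weaker inhibitor of growth, a lower number a stronger inhibitor of growth), compound 2 gives the lower of the two numbers, but the step of a 1.4-fold lower number from compound 1 to compound 2 (0.14 log units; within the scatter) lies within the scatter, so the two compounds are not distinguished. Compound 3 `CN1CCN(CCCOc2cccc3nc(Nc4cccc(Cl)c4)ccc23)CC1` differs from compound 2 by hydrogen in place of chloro on an aromatic carbon. Among the measured compounds shown here, no measured step removes a single chloro group in this way; the only step known exchanged the whole aryl group and changed little, so no clear direction follows. For compound 3 the expected step is a 1.3-fold higher number from compound 2 to compound 3 (0.11 log units; within the scatter), not beyond the scatter. The estimate for compound 3 is 2200 nM, with a range from 900 nM to 5500 nM.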

Compound 3, concentration for 50% growth inhibition: 1780 nM
Compound 3: middle estimate off by 1.2-fold (0.09 log units), on the high side, within the range that was stated.
By their numbers in this assay, from the lowest: compounds 2, 3 and 1 (each within the scatter of the next).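

Taking one chloro group off the 3,5-dichlorophenyl ring gives a 1.0-fold higher number from compound 2 to compound 3 (0.01 log units; within the scatter) in this assay, so for the first time a single atom at this position is isolated, and the two compounds are not distinguished. Exchanging the 3,4-difluorophenyl for 3-chlorophenyl gives a 1.3-fold lower number from compound 1 to compound 3 (0.12 log units; within the scatter), which again does not separate the compounds. No evidence here explains this lack of separation.

Still open, from the compounds shown here alone, is whether an unsubstituted phenyl, or a methoxy, nitrile or amine on this ring, would move the number beyond the scatter.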